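This account rests on a few compounds, and the source may have more. Where it says the series, first, only, none or still open, it means among the compounds named here.

Measured in a physicochemical assay for solubility, read by HPLC, using the shake flask method, measured as kinetic solubility, with a stated time of 20 h, at pH 6.5, tested at 200 uM; on this read-out lower numbers stand for lower solubility and higher numbers for higher solubility:
Compound 1 `O=S(=O)(NCC1COC1)c1cccc(-c2ccc3nccc(-c4ccncc4)c3n2)c1`: 20000 nM
Compound 2 `CS(=O)(=O)Nc1ccc2nccc(-c3ccncc3)c2n1`: 90000 nM

Of these two, compound 1 stands lowest at 20000 nM, while compound 2 reads higher at 90000 nM, a gap beyond the usual scatter. Compound 3 `CS(=O)(=O)c1cccc(-c2ccc3nccc(-c4ccncc4)c3n2)c1` has not yet been measured in this assay. It carries methyl in place of ((oxetan-3-yl)methyl)amino on a sulfonyl sulfur, and the rest of compound 1 stays unchanged. Going by the values given here, no measured pair of compounds shows this exchange, so the expectation is loose. A small downward move is expected, one that would stay within the scatter. The expected step runs a 1.4-fold lower number from compound 1 to compound 3 (0.15 log units; within the scatter). For compound 3 the estimated value is 14000 nM, with an expected range from 4000 nM to 50000 nM.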

Compound 3, solubility: < 5000 nM
Compound 3 gave a limit, no number (the forecaster's own chance of this, stated with the estimate: 5%); middle value at least 2.8-fold (0.44 log units) away from the limit.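

Putting methyl in place of ((oxetan-3-yl)methyl)amino on a sulfonyl sulfur gives, in this assay, an at least 4.0-fold lower number from compound 1 to compound 3 (0.60 log units; beyond the scatter). Going by these compounds alone, this is the first comparison here of compounds that differ in one place, and it shows that the number at this position changes with the group, by a step beyond the usual scatter. Compound 3 gives a limit of the assay and not a number: the limit of < 5000 nM in this assay, at which 1 of the 3 values shown sits.

The compounds shown leave open how much of the step goes with the four-membered non-aromatic ring and how much with the amino nitrogen, which a plain methylamino group on the sulfonyl sulfur would help to separate. From the compounds shown here alone, how an open-chain amine or a carboxylic acid on the ((oxetan-3-yl)methyl)amino side would read also remains open, as does the full size of the step.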